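Swapping a Sulfone for a Sulfonamide on a Shared Core

The compounds below may be only part of what the source reports. "The series", "measured", "known", "first", "only" and "open" are said of these compounds alone.

Compound 1 `CCC(CC)S(=O)(=O)c1ccc(S(=O)(=O)N2CCC[C@@H](C(=O)N3CCN(c4nc(C(C)C)no4)CC3)C2)cc1`: 50 nM
Compound 2 `CCOC(=O)[C@@H]1CCCN(S(=O)(=O)c2ccc(S(=O)(=O)N(CC)CC)cc2C)C1`: 5100 nM

For the measured compounds named here, in a functional assay on MIA PaCa-2 cells (Homo sapiens) for inhibition, read by MTT assay, with a stated time of 7 days (a lower number here means a stronger inhibitor, a higher number a weaker inhibitor), compound 1 gives 50 nM, the lower of the two numbers measured so far. Going by the values given here, compound 2 gives 5100 nM, a gap that lies well beyond the usual scatter; no single-point step connects these two structures, so their values can only be set side by side. Compound 3 `CC(C)NS(=O)(=O)c1ccc(S(=O)(=O)N2CCC[C@@H](C(=O)N3CCN(c4nc(C(C)C)no4)CC3)C2)cc1` has not yet been measured. It differs from compound 1 in one place: isopropylamino in place of pentan-3-yl on a sulfonyl sulfur. Among the compounds with values here, no measured pair shows a change of this kind, so the size of the step is uncertain; a modest move toward a higher number, or none beyond the scatter, seems the most likely outcome. Compound 3 is therefore expected to give roughly 100 nM in this assay, with a range from 25 nM to 400 nM, which corresponds to an expected step of a 2.0-fold higher number from compound 1 to compound 3 (0.30 log units; within the scatter).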

Compound 3, half-maximal inhibitory concentration: 2600 nM
Beside the measured number, compound 3's estimate is 26-fold (1.41 log units) below it, and the stated range ends below it.
By their numbers in this assay, from the lowest: compound 1; then compounds 3 and 2 (each within the scatter of the next).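

In this assay, the pentan-3-yl on the sulfonyl sulfur proves far from interchangeable: with the rest of compound 1 unchanged, isopropylamino in its place gives a 52-fold higher number from compound 1 to compound 3 (1.72 log units; beyond the scatter), a large step. For the compounds shown here, compounds 1 and 2 differ in more than one place, so this pair gives the first direct reading of this position, showing that a small exchange of one all-carbon group for a nitrogen-linked one can have a large effect on the measured number. Nothing measured here explains the size of this step.

The swap changes the linking atom and the carbon group at once, so the two changes cannot yet be told apart. A plain isopropyl group on the same sulfur would show how much of the step goes with the nitrogen, and a cyclopentyl group would test another all-carbon option.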